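Ethoxycarbonyl to carboxy on the shared core

This account rests on a few compounds, and the source may have more. Where it says the series, first, only, none or still open, it means among the compounds named here.

In a functional assay (trachea) with Cavia porcellus as the target (on this read-out higher numbers stand for weaker inhibition and lower numbers for stronger inhibition), compound 1 `CCn1nc(-c2cccnc2)c2ccccc2c1=O` gives 1320 nM and compound 2 `C=CCn1nc(-c2cccnc2)c2ccccc2c1=O` gives 2140 nM. The change between them, a 1.6-fold higher number from compound 1 to compound 2 (0.21 log units; within the scatter), is small. Compound 3 `CCOC(=O)Cn1nc(-c2cccnc2)c2ccccc2c1=O` gives 43700 nM, the highest of the three numbers and so the weakest inhibition here. It stands well apart from the other two: a 33-fold higher number from compound 1 to compound 3 (1.52 log units; beyond the scatter) and a 20-fold higher number from compound 2 to compound 3 (1.31 log units; beyond the scatter) are both large.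

Compound 4 `O=C(O)Cn1nc(-c2cccnc2)c2ccccc2c1=O` differs from compound 3 by hydrogen in place of ethyl on an oxygen next to a carbonyl group. This is hydrogen in place of ethyl on an oxygen next to a carbonyl group, or ethoxycarbonyl to carboxy.

Among the compounds with values here, no measured step makes this exact change, so the evidence is indirect. The two large steps show only that placing ethoxycarbonyl on this chain goes with a much higher number. Compound 4 keeps the carbonyl on that chain, so the anchor is compound 3 at 43700 nM, not the much lower values of the first two compounds. Nothing measured shows how much the ethyl itself contributes, so the range must stay wide.

The expected change is modest and towards a higher number, with a 1.4-fold higher number from compound 3 to compound 4 (0.14 log units; within the scatter) not clearly beyond the scatter. Compound 4 is estimated at 60000 nM, with an expected range of 15000 nM to 250000 nM.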

Compound 4, half-maximal inhibitory concentration: > 100000 nM
Compound 4 was reported as a limit; the forecaster's own chance of this, stated with the estimate: 30%; middle value at least 1.6-fold (0.22 log units) away from the limit.
By their numbers in this assay, from the lowest: compounds 1 and 2 (each within the scatter of the next); then compound 3. At a limit, above all of these: compound 4.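

In this assay, compound 4 is reported only as a limit of the assay, not as a number: the limit of > 100000 nM in this assay, at which 1 of the 4 values shown sits.

Hydrogen in place of ethyl on an oxygen next to a carbonyl group gives an at least 2.2-fold higher number from compound 3 to compound 4 (0.35 log units; beyond the scatter), so losing the ethyl does not bring the number back towards those of the two simple chains. Against those chains the carboxy group stands far off, with an at least 46-fold higher number from compound 2 to compound 4 (1.66 log units; beyond the scatter) and an at least 75-fold higher number from compound 1 to compound 4 (1.87 log units; beyond the scatter), so on the saturated chain carbon bound to an aromatic nitrogen both carbonyl-bearing groups shown, ethoxycarbonyl and carboxy, go with much higher numbers than methyl or vinyl, and no compound shown goes against this.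

As far as these compounds go, how far compound 4 really lies from the others stays open, since the three steps can be read only as minimum sizes. Also open, from the compounds shown here alone, is whether a primary amide, a hydroxyl or an amine on this chain would fall with the carbonyl-bearing groups or with methyl and vinyl, which would show whether the carbonyl itself goes with the higher numbers.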